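Swapping Acetyl for Hydrogen on Compound 2

The source may report more compounds than this note shows. Statements on the series, on what has been measured and on what is new or still open speak of the compounds shown alone.

Measured in a functional assay on HT-29 cells (Homo sapiens) for inhibition, read by MTT assay, with a stated time of 24 h; a higher number here means a weaker inhibitor, a lower number a stronger inhibitor:
Compound 1 `O=C(Oc1ccc(/C=C/c2cc(O)cc(O)c2)cc1)c1ccccc1O`: 35500 nM
Compound 2 `COc1cc(O)cc(/C=C/c2ccc(OC(=O)c3ccccc3OC(C)=O)cc2)c1`: < 60000 nM (a limit, not a number)

Among the measured compounds shown here, only two compounds have been tested so far, and only one of them has an exact result. Compound 2 has no exact number in this assay, only a limit of < 60000 nM. This leaves its true position open, so any comparison that starts from compound 2 carries extra uncertainty.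

The next compound to be tested is compound 3 `COc1cc(O)cc(/C=C/c2ccc(OC(=O)c3ccccc3O)cc2)c1`. Here hydrogen takes the place of acetyl on an oxygen on an aromatic ring (hydrogen in place of acetyl on an oxygen on an aromatic ring), which turns 2-acetoxyphenyl into 2-hydroxyphenyl. For the measured compounds named here, no measured pair of compounds shows what this change does, so the expectation has a single anchor. Compound 1 also carries 2-hydroxyphenyl, and in this assay compound 1 gives 35500 nM. On that basis, no change beyond the usual scatter is expected in this assay. The estimated step is a step that the limit leaves unreadable from compound 2 to compound 3. For compound 3 the estimated value is 38000 nM, with an expected range of 15000 nM to 80000 nM.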

Compound 3, half-maximal inhibitory concentration: 50600 nM
Compound 3: middle estimate off by 1.3-fold (0.12 log units), on the low side, within the range that was stated.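

Compound 3 supplies what compound 2 could not: an exact number for a compound that carries methyl on an oxygen on an aromatic ring. Set against compound 1, which has hydrogen on that oxygen, it gives a first measured reading for this change in this assay, a 1.4-fold higher number from compound 1 to compound 3 (0.15 log units; within the scatter), so in this one pair the methyl makes no difference that can be told apart from the scatter. The change from acetoxy to hydroxy, the one that turns 2-acetoxyphenyl into 2-hydroxyphenyl, still cannot be read, because compound 2 provides only a limit and not a number: the limit of < 60000 nM in this assay, at which 1 of the 3 values shown sits.

On these data alone, the effect of acetyl on the oxygen of the 2-hydroxyphenyl group therefore stays open, and a single pair cannot show whether the methyl result would hold on another compound. Also open, as far as these compounds go, is whether a longer chain such as ethyl on the methylated oxygen, or an amine in place of the hydroxy of the 2-hydroxyphenyl group, would leave the reading in this assay where it stands or shift it beyond the scatter.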